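Swapping a Methyl for Methoxy on Two Related Cores

The compounds below may be only part of what the source reports. "The series", "measured", "known", "first", "only" and "open" are said of these compounds alone.

Of the compounds shown here, three have been tested in an ADME assay on HEK-293T cells (Homo sapiens) for inhibition, read by CCK-8 assay, with a stated time of 48 h, tested at 20 uM; on this read-out lower numbers stand for less inhibition of growth and higher numbers for more inhibition of growth at the one concentration tested. Compound 1 `Cc1ccc(S(=O)(=O)Oc2ccccc2/C=C(\C#N)C(=O)Nc2nnc(Cc3ccc(Cl)cc3)s2)cc1` gives 20% in this assay. Compound 2 `COc1ccc(S(=O)(=O)Oc2ccccc2/C=C(\C#N)C(=O)Nc2nnc(Cc3ccc(Cl)cc3)s2)cc1` differs from compound 1 by methoxy in place of methyl on an aromatic carbon. That change produced a number 6 percentage points higher from compound 1 to compound 2 (within the scatter). Compound 3 `Cc1ccc(Cc2nnc(NC(=O)/C(C#N)=C/c3ccccc3OS(=O)(=O)c3ccc(C)cc3)s2)cc1` differs from compound 1 by methyl in place of chloro on an aromatic carbon. That change produced a number 2 percentage points higher from compound 1 to compound 3 (within the scatter). In this assay compound 3 shows 22%, while compound 2 shows 26%.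

Compound 4 `COc1ccc(S(=O)(=O)Oc2ccccc2/C=C(\C#N)C(=O)Nc2nnc(Cc3ccc(C)cc3)s2)cc1` has not yet been measured. It differs from compound 3 by methoxy in place of methyl on an aromatic carbon, which is the same change at the same kind of place as that between compound 1 and compound 2. The two cores differ as described between compound 1 and compound 3.

The step is expected to be a number 6 percentage points higher from compound 3 to compound 4 (within the scatter), about the size of the earlier one, because that earlier change gave a number 6 percentage points higher from compound 1 to compound 2 (within the scatter) and all three measured values sit within the usual scatter of one another. Compound 4 is therefore estimated at 28% in this assay, with a likely range from 16% to 40%.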

Compound 4, percent growth inhibition at one concentration: 28%
Estimate against measurement, compound 4: no gap at the digits printed; low and high end bracket the measured number.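

In this assay, methoxy in place of methyl gives a number 6 percentage points higher from compound 3 to compound 4 (within the scatter), and this step matches the earlier one on the other core: the same change on two cores in this assay, a number 6 percentage points higher (within the scatter) from compound 1 to compound 2 and a number 6 percentage points higher (within the scatter) from compound 3 to compound 4, 0 percentage points apart, within the scatter of two such steps. Methyl in place of chloro gives a number 2 percentage points higher from compound 2 to compound 4 (within the scatter), and this step repeats as well: the same change on two cores in this assay, a number 2 percentage points higher (within the scatter) from compound 1 to compound 3 and a number 2 percentage points higher (within the scatter) from compound 2 to compound 4, 0 percentage points apart, within the scatter of two such steps. For the compounds shown here, all of these steps lie within the scatter, which means the match shows only that neither swap made a measurable difference on these two cores, not that either swap has a real effect of this size that would carry over to other cores.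

The compounds shown carry only methyl, methoxy or chloro at these positions, leaving open whether a different group, such as an amine or a carboxylic acid, would move the growth inhibition beyond the scatter. Going by these compounds, it also remains open whether these swaps would stay just as small on a core altered elsewhere, for instance with a longer chain.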